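The compounds below may be only part of what the source reports. "The series", "measured", "known", "first", "only" and "open" are said of these compounds alone.

Series notes. Three compounds carry a measured value. Compound 1, `CC1=CC[C@H]2[C@@H]1CC=C(C)[C@@H](CC[C@H]1[C@]3(C)CC[C@H](OC(=O)c4ccncc4)C(C)(C)O[C@H]3CC[C@@]1(C)O)C2(C)C`, gives 19100 nM in a functional assay on MDA-MB-231 cells (Homo sapiens) for antiproliferative activity, read by MTT assay, with a stated time of 72 h; on this read-out lower numbers stand for stronger inhibition and higher numbers for weaker inhibition. Among the measured compounds shown here, compound 2, `CC1=CC[C@H]2[C@@H]1CC=C(C)[C@@H](CC[C@H]1[C@]3(C)CC[C@H](OC(=O)c4ccc(C)cc4)C(C)(C)O[C@H]3CC[C@@]1(C)O)C2(C)C`, gives 32700 nM in this assay, and the step of a 1.7-fold higher number from compound 1 to compound 2 (0.23 log units; within the scatter) is the only single-point change measured so far. Compound 3, `CC1=CC[C@H]2[C@H](CC[C@]2(C)O)C(C)(C)[C@@H]1CC[C@H]1[C@]2(C)CC[C@H](OC(=O)NCc3ccccc3)C(C)(C)O[C@H]2CC[C@@]1(C)O`, gives 40300 nM in this assay; it stands highest of the three numbers, but its gap to compound 2 lies within the scatter and only its gap to compound 1 lies beyond it.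

Compound 4 is `CC1=CC[C@H]2[C@H](CC[C@]2(C)O)C(C)(C)[C@@H]1CC[C@H]1[C@]2(C)CC[C@H](OC(=O)c3ccccc3Cl)C(C)(C)O[C@H]2CC[C@@]1(C)O`. Its change from compound 3 is 2-chlorophenyl in place of benzylamino on a carbonyl carbon. For the measured compounds named here, the one measured step, a 1.7-fold higher number from compound 1 to compound 2 (0.23 log units; within the scatter), sits on the same carbonyl carbon but exchanges one aryl for another and stayed within the scatter; no measured step exchanges an amine-bearing carbonyl for an aryl-bearing one. The expectation therefore rests on compound 1 alone, whose number stands apart from compound 3 beyond the scatter, while compound 2 does not. For compound 4 the expected step is a 1.4-fold lower number from compound 3 to compound 4 (0.16 log units; within the scatter), a shift that may well stay within the scatter. The estimate for compound 4 in this assay is 28000 nM, with a range from 12000 nM to 65000 nM.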

Compound 4, half-maximal inhibitory concentration: 24300 nM
Estimate against measurement, compound 4: 1.2-fold (0.06 log units) above; low and high end bracket the measured number.
By their numbers in this assay, from the lowest: compounds 1, 4, 2 and 3 (each within the scatter of the next, the first and the last beyond it).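

Among the compounds shown here, on this carbonyl carbon, 2-chlorophenyl in place of benzylamino gives a 1.7-fold lower number from compound 3 to compound 4 (0.22 log units; within the scatter) in this assay and this is the first measured exchange of an amine-bearing group for an aryl group here. On the core of compound 3, the carbamate nitrogen and its hydrogen-bond donor can therefore be replaced by a chlorine-bearing aryl group without a shift beyond the scatter, much as the aryl exchange a 1.7-fold higher number from compound 1 to compound 2 (0.23 log units; within the scatter) stayed within it on the core of compound 1. No further data bear on the reason for this result.

Open, going by these compounds, is whether 2-chlorophenyl would read the same on the core of compound 1, which would need a pair differing in that one place. Also open, on these data alone, is how a carboxylic acid, a longer alkyl chain or a free hydroxyl at this position would read against compound 3 and compound 4.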